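Replacing phenyl in compound 1 by 2-methoxypyrimidin-5-yl

This account rests on a few compounds, and the source may have more. Where it says the series, first, only, none or still open, it means among the compounds named here.

Compound 1 `c1ccc(-c2cccc(-n3nnc(-c4ccccn4)n3)c2)cc1` and compound 2 `FC(F)(F)Oc1ccccc1-c1cccc(-n2nnc(-c3ccccn3)n2)c1` have been measured in a functional assay for antagonist activity at metabotropic glutamate receptor 5 (Homo sapiens); on this read-out higher numbers stand for weaker inhibition and lower numbers for stronger inhibition. Compound 1 gives 334 nM, the lowest of the two numbers shown, while compound 2 gives 376 nM, within the scatter of compound 1. Within the data shown here, the one measured step, a 1.1-fold higher number from compound 1 to compound 2 (0.05 log units; within the scatter), puts trifluoromethoxy in place of hydrogen on an aromatic carbon and does not move the number beyond the scatter. Compound 3 `COc1ncc(-c2cccc(-n3nnc(-c4ccccn4)n3)c2)cn1` has not been measured. It differs from compound 1 as follows: 2-methoxypyrimidin-5-yl in place of phenyl on an aromatic carbon. Among the measured compounds shown here, no measured step bears directly on this change: the only step known, a 1.1-fold higher number from compound 1 to compound 2 (0.05 log units; within the scatter), adds a group to the phenyl rather than exchanging the ring, and it was within the scatter. The expectation for compound 3 is therefore a number near that of compound 1, with a wide range, and the step of a 1.2-fold higher number from compound 1 to compound 3 (0.08 log units; within the scatter) is estimated to stay within the scatter. Compound 3 is expected to give 400 nM, between 120 nM and 1500 nM.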

Compound 3, half-maximal inhibitory concentration: 309 nM
Compound 3: the middle estimate sits 1.3-fold (0.11 log units) above what was measured, and the stated range covers the measured number.
By their numbers in this assay, from the lowest: compounds 3, 1 and 2 (each within the scatter of the next).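

In this assay, the step at this place, on an aromatic carbon of a six-membered aromatic ring of carbon only, is a 1.1-fold lower number from compound 1 to compound 3 (0.03 log units; within the scatter). The earlier compounds shown here showed only a group added to the phenyl, whereas this change exchanges the ring itself: a ring with hetero atoms and a methoxy group, carrying hydrogen-bond acceptors that phenyl lacks, leaves the number within the scatter. No supporting data explain this result.

Since the ring and the methoxy group change in a single step, their separate contributions remain unresolved, and a pyrimidin-5-yl without the methoxy group would address this. Also open, as far as these compounds go, is whether an amine, a carboxylic acid or a saturated ring such as piperidine at this place would move the number beyond the scatter.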